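Moving an Amide Across the Core: a Fluorophenyl Analogue

This account rests on a few compounds, and the source may have more. Where it says the series, first, only, none or still open, it means among the compounds named here.

Three compounds were measured in a functional assay on OVCAR-3 cells (Homo sapiens) for antiproliferative activity, read by MTT assay, with a stated time of 24 h; on this read-out lower numbers stand for stronger inhibition and higher numbers for weaker inhibition:

Compound 1, `O=C(NNC(=O)c1cccc(Cl)c1)c1ccc(NS(=O)(=O)c2cnc(O)nc2O)cc1`, gives 7710 nM.
Compound 2, `O=C(NNC(=O)c1ccccc1F)c1ccc(NS(=O)(=O)c2cnc(O)nc2O)cc1`, gives 16000 nM.
Compound 3, `O=C(NNC(=O)c1ccccc1NS(=O)(=O)c1cnc(O)nc1O)c1cccc(Cl)c1`, gives 2080 nM.

Compounds 1 and 2 share one core, and compound 3 is built from the same atoms joined differently; how the two cores differ is not broken down here. Among the three, compound 3 gives the lowest number, and its steps to compound 1 and to compound 2 both lie beyond the usual scatter.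

For the measured compounds named here, the one change seen within the measured set is 2-fluorophenyl in place of 3-chlorophenyl on a carbonyl carbon. On the core of compound 1 this change produced a 2.1-fold higher number from compound 1 to compound 2 (0.32 log units; beyond the scatter), a modest weakening.

Compound 4, `O=C(NNC(=O)c1ccccc1NS(=O)(=O)c1cnc(O)nc1O)c1ccccc1F`, is the matching partner of compound 3: it carries 2-fluorophenyl in place of 3-chlorophenyl on a carbonyl carbon. The place of the change is the same as in the pair of compound 1 and compound 2, so it is the same change, now made on the other core.

The account rests on a single precedent. Because the change from compound 1 to compound 2 gave a 2.1-fold higher number from compound 1 to compound 2 (0.32 log units; beyond the scatter), a step of similar size is expected in this assay from compound 3 to compound 4, namely a 2.1-fold higher number from compound 3 to compound 4 (0.33 log units; beyond the scatter). Compound 4 is therefore estimated at 4400 nM, with the expected range running from 2000 nM to 10000 nM, the width allowing for the change landing on a different core than the one where it was seen.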

Compound 4, half-maximal inhibitory concentration: 15300 nM
Compound 4: middle estimate off by 3.5-fold (0.54 log units), on the low side; measured number above the stated range.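

On the core of compound 3, the change from 3-chlorophenyl to 2-fluorophenyl on a carbonyl carbon gave a 7.4-fold higher number from compound 3 to compound 4 (0.87 log units; beyond the scatter) in this assay, a weakening in the same direction as on the core of compound 1. For the compounds shown here, the direction of the change therefore carried from one core to the other in these two pairs, but its size did not: the same change on two cores in this assay, a 2.1-fold higher number (0.32 log units; beyond the scatter) from compound 1 to compound 2 and a 7.4-fold higher number (0.87 log units; beyond the scatter) from compound 3 to compound 4, 3.5-fold (0.55 log units) apart, beyond the scatter of two such steps The result shows that, in this series, a step measured on one core cannot be taken as a reliable guide to the size of the same step on the other, but with only two pairs it does not show which difference between the cores goes with the larger step, nor whether any other change would behave in the same way.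

The change replaces both the halogen and the group's place on the ring, so the compounds shown leave open how much of either step belongs to each, a question that 2-chlorophenyl or 3-fluorophenyl on both cores could separate. On these data alone, it also remains open how a plain phenyl group, or a phenyl group carrying an amine or a carboxylic acid, would stand at this carbonyl carbon on either core.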